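A few compounds are considered here, and "the series" means these few. Any claim that something is new, unique, unknown or untested is made for them only; others in the source may bear on it.

Compound 1 `Cc1ccsc1-c1cc(-c2ccc(Cl)o2)cc(-c2cccc(Cl)c2)n1` gives 18800 nM in a functional assay on MCF7 cells (Homo sapiens) for cytotoxicity, read by ELISA, with a stated time of 4 days (a higher number here means a weaker inhibitor, a lower number a stronger inhibitor), and compound 2 `Clc1ccc(-c2cc(-c3ccco3)nc(-c3ccc(Cl)s3)c2)o1` gives 16900 nM there, so compound 2 stands level with compound 1 within the scatter. Compound 3 `Clc1cccc(-c2cc(-c3ccc(Cl)o3)cc(-c3ccc(Cl)s3)n2)c1` has 3-chlorophenyl in place of furan-2-yl on an aromatic carbon next to the ring nitrogen (3-chlorophenyl in place of furan-2-yl on an aromatic carbon). Within the data shown here, no measured pair shows this swap on its own. Compound 1 also carries 3-chlorophenyl and gives 18800 nM without standing apart from compound 2, so no step beyond the scatter is expected. The expected step (a 1.4-fold lower number from compound 2 to compound 3 (0.15 log units; within the scatter)) leans slightly towards a lower number. In this assay the estimate for compound 3 is 12000 nM (expected range 4500 nM to 30000 nM).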

Compound 3, half-maximal inhibitory concentration: 15100 nM
Compound 3: middle estimate off by 1.3-fold (0.10 log units), on the low side; the measured number falls inside the stated range.
By their numbers in this assay, from the lowest: compounds 3, 2 and 1 (each within the scatter of the next).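

Furan-2-yl and 3-chlorophenyl can now be compared directly at this position in this assay, and the exchange gives only a small step (a 1.1-fold lower number from compound 2 to compound 3 (0.05 log units; within the scatter)). Exchanging 3-methylthiophen-2-yl for 5-chlorothiophen-2-yl also stays within the scatter (a 1.2-fold lower number from compound 1 to compound 3 (0.10 log units; within the scatter)). Nothing available explains why these exchanges leave the numbers so close. Going by these compounds, it remains open whether a group of a different kind at this position, such as an amine or a carboxylic acid, would give a step beyond the scatter.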